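A few compounds are considered here, and "the series" means these few. Any claim that something is new, unique, unknown or untested is made for them only; others in the source may bear on it.

Measured compounds:
compound 1, `COc1cc(C(=O)c2sc(-c3ccc(Cl)cc3)cc2N)cc(OC)c1OC` — 93 nM
compound 2, `COc1cc(C(=O)c2sc(-c3ccc(F)cc3)cc2N)cc(OC)c1OC` — 20 nM
compound 3, `CCOc1ccc(-c2cc(N)c(C(=O)c3cc(OC)c(OC)c(OC)c3)s2)cc1` — 590 nM

In a functional assay on L1210 cells (Mus musculus) for antiproliferative activity (on this read-out lower numbers stand for stronger inhibition and higher numbers for weaker inhibition), compound 2 gives the lowest number of the three; its nearest neighbour is compound 1 at a 4.7-fold lower number from compound 1 to compound 2 (0.67 log units; beyond the scatter) in the reverse direction, and its furthest is compound 3 at a 30-fold higher number from compound 2 to compound 3 (1.47 log units; beyond the scatter). Compound 4, `COc1ccc(-c2cc(N)c(C(=O)c3cc(OC)c(OC)c(OC)c3)s2)cc1OC`, has not been measured in this assay. It differs from compound 2 in one place: 3,4-dimethoxyphenyl in place of 4-fluorophenyl on an aromatic carbon.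

For the measured compounds named here, two measured steps bear on this change, both replacing a halogen on the same aromatic carbon with an alkoxy group: a 30-fold higher number from compound 2 to compound 3 (1.47 log units; beyond the scatter) and a 6.3-fold higher number from compound 1 to compound 3 (0.80 log units; beyond the scatter). Both point the same way, toward weaker inhibition when an alkoxy group takes the place of a halogen there, with the larger step starting from the fluoro compound. Compound 4 carries two methoxy groups rather than one ethoxy, but the direction is expected to be the same. A weakening step of an 18-fold higher number from compound 2 to compound 4 (1.24 log units; beyond the scatter) is therefore expected. Compound 4 is estimated at 350 nM, within a range of 80 nM to 1500 nM.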

Compound 4, half-maximal inhibitory concentration: 40 nM
Compound 4: the middle estimate sits 8.8-fold (0.94 log units) above what was measured; the whole stated range lies above it.
By their numbers in this assay, from the lowest: compounds 2 and 4 (each within the scatter of the next); then compound 1; then compound 3.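

At this position on the shared core, an alkoxy-bearing phenyl group does not by itself weaken the result in this assay: the step of a 2.0-fold higher number from compound 2 to compound 4 (0.30 log units; within the scatter) leaves 3,4-dimethoxyphenyl and 4-fluorophenyl unseparated. The step of a 15-fold lower number from compound 3 to compound 4 (1.17 log units; beyond the scatter) shows that 4-ethoxyphenyl and 3,4-dimethoxyphenyl give very different outcomes here, and the step of a 2.3-fold lower number from compound 1 to compound 4 (0.37 log units; beyond the scatter) places compound 4 on the stronger side of the chloro compound, so compound 4 goes against any rule that alkoxy groups weaken inhibition at this position. No measurement is available to explain these differences.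

The compounds shown leave open whether a single 4-methoxyphenyl or 3-methoxyphenyl group would behave like 3,4-dimethoxyphenyl or like 4-ethoxyphenyl. They also leave open how a 4-dimethylaminophenyl group would fare at this position.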